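The source may hold more compounds than are shown below. What is called first, only, known or untested is meant among the compounds shown, and "the series" means these compounds.

Compound 1 `COc1ccc(-c2cc3c(OC)cc(OC)cc3n(C)c2=O)cc1` gives 10000 nM in a functional assay on LoVo cells (Homo sapiens) for cytotoxicity, read by colorimetric assay and MTT assay; on this read-out lower numbers stand for stronger inhibition and higher numbers for weaker inhibition. Compound 2 `CCOC(=O)Cn1c(=O)c(-c2ccc(OC)cc2)cc2c(OC)cc(OC)cc21` gives 10000 nM in this assay, and compound 3 `COc1ccc(-c2cc3c(OC)cc(OC)cc3n(CCC(=O)OCc3ccccc3)c2=O)cc1` gives 10000 nM in this assay. Compound 1 thus stands level with compounds 2 and 3, as the steps of no change at the digits printed from compound 1 to compound 2 (within the scatter) and no change at the digits printed from compound 1 to compound 3 (within the scatter) show, and no change at the digits printed from compound 2 to compound 3 (within the scatter) agrees. Compound 4 `COc1cc(OC)c2cc(-c3ccc(OC(C)=O)cc3)c(=O)n(C)c2c1` differs from compound 1 by acetyl in place of methyl on an oxygen on an aromatic ring. None of the three measured steps touches this position: each of them alters the group on a saturated chain carbon bound to an aromatic nitrogen and leaves the oxygen on the aromatic ring untouched. For the measured compounds named here, the record therefore offers no step that bears directly on the change from methoxy to acetoxy, while the shared core has returned one and the same reading under every substitution tried so far. On that basis no step beyond the scatter is expected in this assay: no change at the digits printed from compound 1 to compound 4 (within the scatter). Compound 4 is accordingly estimated at 10000 nM, within a range of 3000 nM to 30000 nM.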

Compound 4, half-maximal inhibitory concentration: 10000 nM
Compound 4: the middle estimate sits on the measured number at the digits printed; measured number inside the range.
By their numbers in this assay, from the lowest: compounds 1, 2, 3 and 4 (each within the scatter of the next).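

For the compounds shown here, replacing methyl with acetyl on an oxygen on an aromatic ring gives no change at the digits printed from compound 1 to compound 4 (within the scatter) in this assay, so this position now has a reading of its own, where the earlier steps spoke only to the group on a saturated chain carbon bound to an aromatic nitrogen. The change from methoxy to acetoxy adds a carbonyl and, by the count for the two groups, a hydrogen-bond acceptor, yet the printed reading stays the same. Nothing on hand offers an explanation for this outcome.

The compounds shown leave open whether a free hydroxyl, an amine or a longer acyl chain on this oxygen-bearing ring carbon would read any differently from compound 4. With all four compounds at one printed value, they also leave open whether a change at the other methoxy groups of the shared core would move the reading at all.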